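A few compounds are considered here, and "the series" means these few. Any claim that something is new, unique, unknown or untested is made for them only; others in the source may bear on it.

Working notes on the series. Two compounds carry numbers in a functional assay on DU-145 cells (Homo sapiens) for inhibition, read by trypan blue exclusion, with a stated time of 96 h; a lower number here means a stronger inhibitor of growth, a higher number a weaker inhibitor of growth. Compound 1 `COc1cc(OC)c(/C=C(/SCc2ccc(Cl)c(Cl)c2)C(=O)c2ccc(Cl)cc2)c(OC)c1` gives 10000 nM in this assay, the highest of the two numbers. For the measured compounds named here, compound 2 `Cc1ccc(CS/C(=C/c2cc([N+](=O)[O-])ccc2F)C(=O)c2ccc(Cl)cc2)cc1` gives 1000 nM in this assay, a lower number that lies beyond the scatter; compound 2 differs from compound 1 in more than one place, so no single structural step can be tied to that gap.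

Compound 3 `COc1cc(OC)c(/C=C(/Sc2ccc(C)cc2)C(=O)c2ccc(Cl)cc2)c(OC)c1` has not yet been measured in this assay. Its change from compound 1 is 4-methylphenyl in place of 3,4-dichlorobenzyl on a sulfur. Going by the values given here, nothing among the measured pairs isolates this change, and compound 2 carries a sulfur substituent of its own but also other differences, so the data give no direct reading of the substituent on sulfur alone.

The number for compound 3 is expected to move somewhat below that of compound 1, with the expected step of a 2.0-fold lower number from compound 1 to compound 3 (0.30 log units; within the scatter) in this assay lying at or just beyond the scatter. In this assay compound 3 is estimated at 5000 nM, with a range from 1500 nM to 15000 nM.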

Compound 3, concentration for 50% growth inhibition: > 100000 nM
Compound 3: a limit, no number; the forecaster's own chance of this, stated with the estimate: 10%; middle value at least 20-fold (1.30 log units) away from the limit.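

Compound 3 gives > 100000 nM in this assay, and this value is a limit of the assay, not a number. For the compounds shown here, this is the first change that can be read on its own: with the rest of the core of compound 1 held constant, 4-methylphenyl in place of 3,4-dichlorobenzyl on a sulfur gives an at least 10-fold higher number from compound 1 to compound 3 (1.00 log units; beyond the scatter), so growth inhibition in this assay depends on the group at this position, a dependence that the gap between the two earlier compounds could not show. Only the lower end of this step can be read, and its full size remains unknown: the limit of > 100000 nM in this assay, at which 1 of the 3 values shown sits.

The change alters two features at once, removing the carbon link between sulfur and ring and replacing the two chlorines with a methyl, so the compounds shown do not say which of these matters. A 4-methylbenzyl or 3,4-dichlorophenyl group on the same sulfur of the core of compound 1 would separate the two features, while a 2-phenylethyl chain there would show whether a longer link is accepted.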